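A few compounds are considered here, and "the series" means these few. Any claim that something is new, unique, unknown or untested is made for them only; others in the source may bear on it.

Measured compounds in a functional assay on MCF7 cells (Homo sapiens) for inhibition, read by MTT assay, with stated times of 18 h and 4 h; on this read-out higher numbers stand for weaker inhibition and lower numbers for stronger inhibition:
compound 1, `CCCCCCCCCCCCCCCCOP(=O)(O)OCCSC(=S)N1CCN(C)CC1`: a limit only, > 100000 nM
compound 2, `CCCCCCOP(=O)(O)OCCSC(=S)N1CCCCC1`: 62000 nM
compound 3, `CCCCCCCCCCCCCCCCOP(=O)(O)OCCSC(=S)N1CCCCC1`: 29000 nM

The value of compound 1 is a limit of this assay and not a number (the limit of > 100000 nM in this assay, at which 1 of the 3 values shown sits). Compound 3 and compound 1 differ by 4-methylpiperazin-1-yl in place of piperidin-1-yl on a thiocarbonyl carbon; this step gives an at least 3.4-fold higher number from compound 3 to compound 1 (0.53 log units; beyond the scatter). The two cores, those of compound 3 and compound 2, differ by hydrogen in place of decyl on a saturated chain carbon, six bonds along the chain from an oxygen on an unsaturated carbon; here a 2.1-fold lower number from compound 2 to compound 3 (0.33 log units; beyond the scatter). Of the two values read as numbers, compound 2 carries the higher one.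

Compound 4, `CCCCCCOP(=O)(O)OCCSC(=S)N1CCN(C)CC1`, has not yet been measured. It differs from compound 2 by 4-methylpiperazin-1-yl in place of piperidin-1-yl on a thiocarbonyl carbon, the same change as from compound 3 to compound 1, at the same place. Carrying that measured step over onto the number of compound 2 would take compound 4 past the value at which compound 1 was reported as a limit. Compound 4 is therefore expected to give 200000 nM in this assay, most likely reported as a limit only, within an estimated range of 80000 nM to 600000 nM. The expected step of a 3.2-fold higher number from compound 2 to compound 4 (0.51 log units; beyond the scatter) rests on the measured at least 3.4-fold higher number from compound 3 to compound 1 (0.53 log units; beyond the scatter).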

Compound 4, half-maximal inhibitory concentration: 58000 nM
The estimate for compound 4 lay 3.4-fold (0.54 log units) above the measured number, outside the stated range (below it).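

On the core of compound 2, 4-methylpiperazin-1-yl in place of piperidin-1-yl on a thiocarbonyl carbon gives a 1.1-fold lower number from compound 2 to compound 4 (0.03 log units; within the scatter), so in this assay this change does not carry over from one core to the other at a constant size: the same change on two cores in this assay, an at least 3.4-fold higher number (0.53 log units; beyond the scatter) from compound 3 to compound 1 and a 1.1-fold lower number (0.03 log units; within the scatter) from compound 2 to compound 4, at least 3.6-fold (0.56 log units) apart, beyond the scatter of two such steps. Read along the chain, the same two pairs give an at least 1.7-fold lower number from compound 1 to compound 4 (0.23 log units; that floor lies within the scatter), which also differs from the step between the piperidin-1-yl compounds: the same change on two cores in this assay, a 2.1-fold lower number (0.33 log units; beyond the scatter) from compound 2 to compound 3 and an at least 1.7-fold higher number (0.23 log units; that floor lies within the scatter) from compound 4 to compound 1, at least 3.6-fold (0.56 log units) apart, beyond the scatter of two such steps. The value of compound 1, > 100000 nM, is a limit and not a number, so these pairs show that the step depends on the core here, but not how large the gap truly is, nor whether it holds beyond these four compounds.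

Open is whether the step shifts gradually with chain length, which a chain such as dodecyl in place of the chains shown could test. Also open, going by these compounds, is how other amines on a thiocarbonyl carbon, such as morpholin-4-yl or diethylamino, would behave on each core.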